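Swapping the aryl group on a carbamate side chain

This account rests on a few compounds, and the source may have more. Where it says the series, first, only, none or still open, it means among the compounds named here.

Compound 2 `COc1cccc(NC(=O)Oc2cc(=O)n(CCCO)c3c2CC(C/C=C(\C)CCC=C(C)C)C(C)(C)C3)c1` has the higher of the two numbers measured in a functional assay on PANC-1 cells (Homo sapiens) for inhibition, read by MTT assay, with a stated time of 24 h, tested at 10 uM; a lower number here means less inhibition, a higher number more inhibition at the concentration tested (going by the name of the read-out): compound 2 gives 47%. Compound 1 `COc1ccc(OCCCOc2cc(=O)n(CCCO)c3c2CC(C/C=C(\C)CCC=C(C)C)C(C)(C)C3)cc1` shares the same core but carries a 3-(4-methoxyphenoxy)propyl group where compound 2 carries a (3-methoxyphenyl)carbamoyl group; in this assay compound 1 gives 20%. Within the data shown here, the one measured step, a number 27 percentage points higher from compound 1 to compound 2 (beyond the scatter), is therefore an exchange of that whole side chain. Compound 3 `CC(C)=CCC/C(C)=C/CC1Cc2c(OC(=O)Nc3ccc(Cl)cc3)cc(=O)n(CCCO)c2CC1(C)C` keeps the carbamate of compound 2 and alters only the aromatic ring on its nitrogen: 4-chlorophenyl in place of 3-methoxyphenyl on an amide-type nitrogen. Among the measured compounds shown here, no measured pair shows a change of this kind; the step from compound 1 to compound 2 concerns the chain as a whole, not the ring at its end, so it gives no guide to size or direction here. With nothing to lean on, the expectation is a step no larger than the usual scatter, in either direction, and compound 3 is expected to give 45%, within 25% to 65%. The expected step is thus a number 2 percentage points lower from compound 2 to compound 3 (within the scatter).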

Compound 3, a percentage reported as inhibition, at one concentration (the size of the read-out at that concentration, not a potency): 47.2%
For compound 3 the middle estimate is 2.2 percentage points below the measured one; the range from low to high includes it.
By their numbers in this assay, from the lowest: compound 1; then compounds 2 and 3 (each within the scatter of the next).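

In this assay, 4-chlorophenyl in place of 3-methoxyphenyl on the amide-type nitrogen gives a number 0.2 percentage points higher from compound 2 to compound 3 (within the scatter) and so leaves compounds 2 and 3 indistinguishable, even though 3-methoxyphenyl has one hydrogen-bond acceptor and 4-chlorophenyl has none. The comparison with the ether side chain also gains a second example: a number 27.2 percentage points higher from compound 1 to compound 3 (beyond the scatter) is beyond the scatter, as is a number 27 percentage points higher from compound 1 to compound 2 (beyond the scatter), so among these three compounds the difference from compound 1 does not rest on a single aromatic ring attached to the carbamate. No independent measurement is available to explain why these two aromatic rings give results that cannot be told apart.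

Only two substituted phenyl rings appear on this nitrogen, and they differ in both the group carried and the number in the name, so the compounds shown cannot separate those two features. On these data alone, it remains open whether the same picture would hold for an unsubstituted phenyl ring, a phenyl ring bearing an amine or a carboxylic acid, or a longer carbon chain connecting the amide-type nitrogen to the ring.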